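This account rests on a few compounds, and the source may have more. Where it says the series, first, only, none or still open, it means among the compounds named here.

Compound 1 `CC#C[C@H]1CN(S(=O)(=O)c2ccc(N)nc2)CCN1c1ccc([C@@](O)(CO)C(F)(F)F)cc1`: 89 nM
Compound 2 `CC#C[C@H]1CN(S(=O)(=O)c2ccc(N)nc2)CCN1c1ccc(S(N)(=O)=O)cc1`: 37 nM
Compound 3 `CC#C[C@H]1CN(S(=O)(=O)c2ccc(N)nc2)CCN1c1ccc(S(=O)(=O)Nc2ccccc2)cc1`: a limit of the assay, > 12500 nM

In an assay on cells (Hepatocyte) for inhibition of glucokinase regulatory protein (Mus musculus), with stated times of 20 min and 40 min (a higher number here means that more compound is needed for the effect, a lower number that less compound is needed), compound 1 gives 89 nM and compound 2 gives 37 nM, with a 2.4-fold lower number from compound 1 to compound 2 (0.38 log units; beyond the scatter). For compound 3 only a limit of the assay is known, so compound 3 stands at the limit of > 12500 nM in this assay, at which 1 of the 3 values shown sits. Compound 4 `CC#C[C@H]1CN(S(=O)(=O)c2ccc(N)nc2)CCN1c1ccc(S(=O)(=O)NCC2CC2)cc1` carries cyclopropylmethyl in place of phenyl on a sulfonamide nitrogen. The measured step that bears on this place is an at least 330-fold higher number from compound 2 to compound 3 (2.52 log units; beyond the scatter), a large rise when phenyl entered on that sulfonamide nitrogen. With cyclopropylmethyl in place of phenyl, compound 4 is expected to give back part of that rise, a step of an at least 4.1-fold lower number from compound 3 to compound 4 (0.61 log units; beyond the scatter) from the limit. Compound 4 is therefore estimated at 3000 nM, between 500 nM and 15000 nM.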

Compound 4, half-maximal effective concentration: 271 nM
Compound 4: middle estimate off by 11-fold (1.04 log units), on the high side, outside the stated range (below it).
By their numbers in this assay, from the lowest: compound 2; then compound 1; then compound 4. At a limit, above all of these: compound 3.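

In this assay, the sharp loss with phenyl on the sulfonamide nitrogen proves not to hold for every substituent there, with cyclopropylmethyl giving an at least 46-fold lower number from compound 3 to compound 4 (1.66 log units; beyond the scatter). Compound 3 is known only as a limit of the assay: the limit of > 12500 nM in this assay, at which 1 of the 4 values shown sits. Cyclopropylmethyl still does not match the unsubstituted sulfonamide, with a 7.3-fold higher number from compound 2 to compound 4 (0.86 log units; beyond the scatter), and it also falls short of the group carried by compound 1, with a 3.0-fold higher number from compound 1 to compound 4 (0.48 log units; beyond the scatter). Going by these compounds, whether a methyl, a longer alkyl chain or a benzyl on this nitrogen would stay near compound 4 or move towards compound 3 remains open.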